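This account rests on a few compounds, and the source may have more. Where it says the series, first, only, none or still open, it means among the compounds named here.

Compounds measured so far:
- compound 1, `CCc1nc2c(-c3ccc(Cl)cc3Cl)ccnc2n1C(CCOC)C1CC1`: 1.5 nM
- compound 2, `CCC(CCOC)n1c(C2CC2)nc2c(-c3ccc(C(F)(F)F)cc3Cl)ccnc21`: 20.8 nM
- compound 3, `CCCC(C)n1c(CC)nc2c(-c3ccc(OC)cc3C(F)(F)F)ccnc21`: 0.74 nM

All three were tested in an assay for binding affinity to Corticotropin releasing factor receptor (Rattus norvegicus); a higher number here means a weaker inhibitor, a lower number a stronger inhibitor. Compound 1 sits second highest of the three numbers; compound 3 gives a lower number beyond the usual scatter, while compound 2 lies well above. Compound 4, `CCc1nc2c(-c3ccc(Cl)cc3Cl)ccnc2n1C(CC)CC`, has not been measured in this assay yet. It differs from compound 1 in one place: pentan-3-yl in place of 1-cyclopropyl-3-methoxypropyl on an aromatic nitrogen. Among the compounds with values here, no measured pair shows this exact change, so the step is a guess resting on the shared core, which compound 1 shows binds tightly. For the step from compound 1 to compound 4 in this assay a change within the scatter is expected, in no fixed direction, so a 1.3-fold higher number from compound 1 to compound 4 (0.12 log units; within the scatter). Compound 4 is thus estimated at 2 nM, in the range 0.6 nM to 7 nM.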

Compound 4, inhibition constant: 1 nM
Compound 4: middle estimate off by 2.0-fold (0.30 log units), on the high side, within the range that was stated.
By their numbers in this assay, from the lowest: compounds 3, 4 and 1 (each within the scatter of the next, the first and the last beyond it); then compound 2.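

In this assay, placing pentan-3-yl instead of 1-cyclopropyl-3-methoxypropyl on the aromatic nitrogen gives a 1.5-fold lower number from compound 1 to compound 4 (0.18 log units; within the scatter), so the two numbers cannot be told apart. On this core, then, tight binding does not depend on the three-membered ring or on the oxygen of the group that leaves. Nothing available explains this result.

From the compounds shown here alone, whether this nitrogen would accept a group bearing an amine or a carboxylic acid, or a much longer chain, remains open. So does whether pentan-3-yl would behave alike on the core of compound 2.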